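The source may hold more compounds than are shown below. What is called first, only, known or untested is meant among the compounds shown, and "the series" means these compounds.

Compound 1 `CC(C)(C)c1ccc(CN2C(=O)S/C(=C\c3ccc(N)cc3)C2=O)cc1` was tested in a functional assay on FM3A cells (Mus musculus) for cytotoxicity, read by cell counting, with a stated time of 2 days (on this read-out lower numbers stand for stronger inhibition and higher numbers for weaker inhibition), where compound 1 gives 80000 nM. Two relatives have been measured alongside it. Compound 3 `CC(C)(C)c1ccc(CN2C(=O)S/C(=C\c3cccc(N)c3)C2=O)cc1` carries the amino group on a different position of the same phenyl, and in this assay compound 3 gives 188000 nM. Compound 2 `C=C(Br)C(=O)Nc1ccc(/C=C2\SC(=O)N(Cc3cccc(Cl)c3)C2=O)cc1`, a different variant of the shared core, gives 6100 nM in this assay. Among these three numbers compound 1 holds the second highest; its nearest neighbour is compound 3, reached by a 2.4-fold higher number from compound 1 to compound 3 (0.37 log units; beyond the scatter), while compound 2 sits far lower, as its value shows.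

Compound 4 `Nc1ccc(/C=C2\SC(=O)N(Cc3ccccc3)C2=O)cc1` is not yet measured. It differs from compound 1 by hydrogen in place of tert-butyl on an aromatic carbon. Going by the values given here, no measured step touches this position: the only step in hand, the one from compound 1 to compound 3, moves an amino group on a different ring and was modest. Nothing here points in either direction, so no step beyond the scatter is expected.

For compound 4 the expected value is 80000 nM, with a range of 30000 nM to 200000 nM, amounting to no change at the digits printed from compound 1 to compound 4 (within the scatter) as the estimated step.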

Compound 4, half-maximal inhibitory concentration: 24000 nM
The estimate for compound 4 lay 3.3-fold (0.52 log units) above the measured number; measured number outside the range, below it.
By their numbers in this assay, from the lowest: compound 2; then compound 4; then compound 1; then compound 3.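

In this assay, hydrogen in place of tert-butyl gives a 3.3-fold lower number from compound 1 to compound 4 (0.52 log units; beyond the scatter), so the lower number goes with the loss of the large group. Going by these compounds alone, the earlier step concerned only the amino group on the other aromatic ring, so this is the first sign that the ring carrying the tert-butyl also affects the read-out, and that the tert-butyl is not required for compound 4 to inhibit these cells. Nothing measured here explains why the number falls.

A single replacement cannot show how the number follows the group at this carbon: a methyl group, a methoxy group or a carboxylic acid there could fall near either compound 4 or compound 1. Going by these compounds, it also remains open whether the same replacement would shift the number similarly in compound 3.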